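Methyl Substitution on Arylalkyne Acids: Receptor Agonism Notes

The compounds below may be only part of what the source reports. "The series", "measured", "known", "first", "only" and "open" are said of these compounds alone.

Three acids of a shared arylalkyne scaffold have been measured in an in vitro functional assay on 1321-N1 cells for agonist activity at Free fatty acid receptor 1 (Homo sapiens), read by fluorescence, spectrophotometry and calcium flux; on this read-out lower numbers stand for an effect already at smaller amounts and higher numbers for an effect only at larger amounts of compound. Compound 2 `O=C(O)CCc1ccc(C#Cc2ccnc(-c3ccccc3)c2)cc1` gives 186 nM in this assay. Compound 1 `Cc1ccccc1-c1cc(C#Cc2ccc(CCC(=O)O)cc2)ccn1` differs from compound 2 by methyl in place of hydrogen on an aromatic carbon; in this assay compound 1 gives 1070 nM, and the step is a 5.8-fold higher number from compound 2 to compound 1 (0.76 log units; beyond the scatter). Compound 3 `O=C(O)CCc1ccc(C#Cc2ccccn2)cc1` gives 13200 nM, the highest number of the three, and how its core differs from that of compound 2 is not broken down here.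

Compound 4 `Cc1cccc(C#Cc2ccc(CCC(=O)O)cc2)n1` awaits measurement in this assay. It differs from compound 3 by methyl in place of hydrogen on an aromatic carbon. Within the data shown here, this is the same kind of change as the one that separates compound 1 from compound 2, but not the same: in compound 1 the methyl sits on a six-membered aromatic ring of carbon only, ortho to a large group, whereas in compound 4 it sits on a six-membered aromatic ring with one nitrogen, next to the ring nitrogen and meta to a large group. Among the measured compounds shown here, the only precedent for adding a methyl is the step that gave a 5.8-fold higher number from compound 2 to compound 1 (0.76 log units; beyond the scatter), at that different place, and nothing else here bears on the new position.

For compound 4 the expected step is a 1.1-fold higher number from compound 3 to compound 4 (0.06 log units; within the scatter). That expectation rests on the earlier methyl addition, which gave a 5.8-fold higher number from compound 2 to compound 1 (0.76 log units; beyond the scatter) at a place unlike this one, so a smaller or similar move is anticipated rather than a larger one. Compound 4 is accordingly estimated at 15000 nM, with a likely range from 5000 nM to 45000 nM.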

Compound 4, half-maximal effective concentration: 6170 nM
Estimate against measurement, compound 4: 2.4-fold (0.39 log units) above; the range from low to high includes it.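

In this assay, methyl in place of hydrogen on an aromatic carbon, here on a six-membered aromatic ring with 1 nitrogen and next to the ring nitrogen, gives a 2.1-fold lower number from compound 3 to compound 4 (0.33 log units; beyond the scatter). Set beside the earlier methyl addition, the change does not carry over from one core to the other, neither in direction nor in size: the same change on two cores in this assay, a 5.8-fold higher number (0.76 log units; beyond the scatter) from compound 2 to compound 1 and a 2.1-fold lower number (0.33 log units; beyond the scatter) from compound 3 to compound 4, 12-fold (1.09 log units) apart, beyond the scatter of two such steps. This shows that the outcome of adding a methyl in this series cannot be read across from one core to the other, but it does not show whether the core or the place of the methyl sets the outcome, since the two methyl groups differ in both, and two steps give no rule for any further core.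

The compounds shown leave open what the same methyl placement would do on the core of compound 2, and what a methyl would do on the core of compound 3 at other ring carbons, a comparison that would separate place from core. They also leave open whether another group at the carbon carrying the methyl in compound 4, such as an ethyl, a methoxy or a chlorine, would follow the methyl or depart from it.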